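Lengthening the Chloroacyl Chain on a Second Core

The source may hold more compounds than are shown below. What is called first, only, known or untested is meant among the compounds shown, and "the series" means these compounds.

Compounds 1 and 2 share one core and compounds 3 and 4 another; the difference between the two cores is not broken down here. Compound 1 `O=C(CSc1nnc(NC(=O)CCl)s1)Nc1ccc(Br)cn1` and compound 2 `O=C(CSc1nnc(NC(=O)CCCl)s1)Nc1ccc(Br)cn1` were both tested in a functional assay on HeLa cells (Homo sapiens) for antiproliferative activity, read by MTT assay, with a stated time of 48 h; on this read-out lower numbers stand for stronger inhibition and higher numbers for weaker inhibition. In this assay compound 1 gives 3400 nM, and compound 2 gives 5300 nM. The structural change between them is chloromethyl in place of chloro on a saturated chain carbon bound to a carbonyl carbon The measured step is a 1.6-fold higher number from compound 1 to compound 2 (0.19 log units; within the scatter).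

Compound 3 `O=C(CCl)Nc1ccc(SCC(=O)Nc2cc(Cl)ccn2)cc1` carries the chloro group on the second core. In this assay compound 3 gives 2800 nM. The numbers of compound 3, compound 1 and compound 2 all lie within the usual scatter of one another, so no order among them can be read from these data.

Compound 4 `O=C(CCCl)Nc1ccc(SCC(=O)Nc2cc(Cl)ccn2)cc1` has not yet been measured in this assay. It differs from compound 3 by chloromethyl in place of chloro on a saturated chain carbon bound to a carbonyl carbon This is the same change, at the same place, that separates compound 2 from compound 1. Because a 1.6-fold higher number from compound 1 to compound 2 (0.19 log units; within the scatter) lies within the scatter, compound 4 is expected to give a number close to that of compound 3, and any move is expected to be a slightly higher number. Compound 4 is estimated at 4400 nM, with a likely range from 2200 nM to 8800 nM. Among the measured compounds shown here, the expected step is a 1.6-fold higher number from compound 3 to compound 4 (0.20 log units; within the scatter), which rests on a 1.6-fold higher number from compound 1 to compound 2 (0.19 log units; within the scatter) as the one earlier instance of this change.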

Compound 4, half-maximal inhibitory concentration: 21700 nM
For compound 4 the middle estimate is 4.9-fold (0.69 log units) below the measured one; the measured number lies above the stated range.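

In this assay, the step from chloromethyl to 2-chloroethyl on the core of compound 3 is a 7.8-fold higher number from compound 3 to compound 4 (0.89 log units; beyond the scatter), and it does not match the step seen for the same change on the core of compound 1: the same change on two cores in this assay, a 1.6-fold higher number (0.19 log units; within the scatter) from compound 1 to compound 2 and a 7.8-fold higher number (0.89 log units; beyond the scatter) from compound 3 to compound 4, 5.0-fold (0.70 log units) apart, beyond the scatter of two such steps The size of this change therefore did not carry over from one core to the other, and the small step on the first core would have been a poor guide to the large one on the second. Among the compounds shown here, what this does not show is why the two cores part ways, or whether the difference is a general feature of these cores, since it rests on only one pair of compounds on each core, and the step on the core of compound 1 is too small to establish a shared direction.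

The compounds shown leave open whether a longer chain, such as 3-chloropropyl, would raise the number further on the core of compound 3 or would show a similar step on the core of compound 1. They also leave open whether the gap between the two cores would persist with a bromine or an amine in place of the chlorine on the chain.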